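The compounds below may be only part of what the source reports. "The series", "measured", "known", "first", "only" and "open" are said of these compounds alone.

Three compounds of a shared core were measured in a functional assay on MCF7 cells (Homo sapiens) for cytotoxicity; on this read-out lower numbers stand for an effect already at smaller amounts and higher numbers for an effect only at larger amounts of compound. Compound 1 `COc1cc(Cc2nc3c(N)ncnc3n2CCCCO)cc(OC)c1OC` gives 76900000 nM. Compound 2 `COc1cc(Cc2nc3c(N)ncnc3n2CC(C)CO)cc(OC)c1OC` gives 49100000 nM, and the step of a 1.6-fold lower number from compound 1 to compound 2 (0.19 log units; within the scatter) is within the scatter. Compound 3 `CCCCCn1c(Cc2cc(OC)c(OC)c(OC)c2)nc2c(N)nc(F)nc21` gives 286000000 nM, the highest number of the three; the value of compound 1 lies nearer to it and that of compound 2 further away, and both gaps lie beyond the scatter.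

Compound 4 `COc1cc(Cc2nc3c(N)nc(F)nc3n2CC2CCCO2)cc(OC)c1OC` differs from compound 3 in one place: oxolan-2-yl in place of butyl on a saturated chain carbon bound to an aromatic nitrogen. Within the data shown here, the only measured step at the same place, a saturated chain carbon bound to an aromatic nitrogen, is the one between compound 1 and compound 2, and it stayed within the scatter. Among the measured compounds shown here, no measured step shows a ring entering at this place, so the data give no ground for a shift in either direction. Compound 4 is therefore expected to give about 220000000 nM in this assay, within a range from 60000000 nM to 700000000 nM. This estimate means a step of a 1.3-fold lower number from compound 3 to compound 4 (0.11 log units; within the scatter), which is expected to stay within the scatter.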

Compound 4, half-maximal effective concentration: 147000000 nM
The estimate for compound 4 lay 1.5-fold (0.18 log units) above the measured number; low and high end bracket the measured number.
By their numbers in this assay, from the lowest: compounds 2, 1, 4 and 3 (each within the scatter of the next, the first and the last beyond it).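

In this assay, the exchange of butyl for oxolan-2-yl gave a 1.9-fold lower number from compound 3 to compound 4 (0.29 log units; within the scatter). Among these compounds, the earlier step at this place, on a saturated chain carbon bound to an aromatic nitrogen, involved open chains only, so this is the first reading of a ring there: a five-membered non-aromatic ring with a hydrogen-bond acceptor enters, and the two numbers stay within the scatter of each other. Nothing measured here explains this result.

As far as these compounds go, what an amine or a carboxylic acid at this place would give, or a chain longer than pentyl, remains open. From the compounds shown here alone, it also remains open whether oxolan-2-yl would give a similar result on the core of compound 1.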